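The compounds below may be only part of what the source reports. "The series", "measured", "known", "first", "only" and "open" are said of these compounds alone.

Three thiazolidinone derivatives of the shared core have been measured in a functional assay on NCI-H292 cells (Homo sapiens) for cytotoxicity, read by MTT assay, with a stated time of 72 h, tested at 1.25 ug/mL; a higher number here means more inhibition of growth at the concentration tested, a lower number less inhibition of growth. Compound 1 `O=C1NC(=S)/C(=C/c2ccc(Cl)cc2)S1` gives 10% in this assay. Compound 2 `O=C1NC(=S)/C(=C/c2cccc(F)c2)S1` gives 2.1% in this assay, and compound 3 `O=C1NC(=S)/C(=C/c2ccccc2F)S1` gives 4.29% in this assay. The number of compound 1 is the highest of the three, yet its gap to compound 3 and its gap to compound 2 both lie within the usual scatter of such measurements, so the three compounds cannot be told apart on these figures; all of them sit near the bottom of the range that this assay can report at the concentration used.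

Compound 4 `O=C1NC(=S)/C(=C/c2ccc(Cl)c(Cl)c2)S1` has not been measured. It differs from compound 1 in one place: chloro in place of hydrogen on an aromatic carbon. Among the compounds with values here, no pair of measured compounds differs in a single place, so there is no measured step to lean on for this change. Because compound 1 sits at 10% and all three measured numbers are low, the step from compound 1 to compound 4 is expected to be small, in either direction, and most likely not beyond the scatter, as a number 4 percentage points higher from compound 1 to compound 4 (within the scatter) expresses. The growth inhibition of compound 4 in this assay is therefore estimated at 14%, with a range from 0% to 35%.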

Compound 4, percent growth inhibition at one concentration: 9.18%
Estimate against measurement, compound 4: 4.8 percentage points above, and the stated range covers the measured number.
By their numbers in this assay, from the lowest: compounds 2, 3, 4 and 1 (each within the scatter of the next).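

In this assay, within the data shown here, chloro in place of hydrogen on an aromatic carbon, ortho to a chloro group and meta to a group of 8 heavy atoms, gives a number 0.8 percentage points lower from compound 1 to compound 4 (within the scatter) and provides the first step that can be read between two compounds differing in one place. This single step shows that adding this chloro group at this position does not separate compound 4 from compound 1 at the concentration tested, and both compounds remain among the low numbers seen so far. Nothing available bears on the reason for this result.

The compounds shown leave open whether a different group at this same position, such as an amine, a methoxy group or a carboxylic acid, would produce a step beyond the scatter. They also leave open whether a longer chain in place of the amide hydrogen of the shared core would change the number in this assay by more than the second chloro group does.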